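The compounds below may be only part of what the source reports. "The series", "measured", "known", "first", "only" and "open" are said of these compounds alone.

Measured so far:
compound 1 `COc1ccc(SCc2ccc(C(=O)Nc3ccccc3N)cc2)cc1`: 2390 nM
compound 2 `Cc1ccc(SCc2ccc(C(=O)Nc3ccccc3N)cc2)cc1`: 4250 nM

Both values come from a functional assay on HeLa cells (Homo sapiens) for antiproliferative activity, read by CCK-8 assay, with a stated time of 72 h; on this read-out lower numbers stand for stronger inhibition and higher numbers for weaker inhibition. For the measured compounds named here, compound 1 cannot be separated from compound 2, the only other compound measured.

Compound 3 `COc1ccc(SCc2ccc(C(=O)Nc3ccccc3N)cc2)cc1OC` differs from compound 1 by one change: methoxy in place of hydrogen on an aromatic carbon. This puts methoxy in place of hydrogen on an aromatic carbon, ortho to a methoxy group. Going by the values given here, the only measured step is a different change on the same ring, methyl in place of methoxy: a 1.8-fold higher number from compound 1 to compound 2 (0.25 log units; within the scatter). This gives weak guidance, and a step beyond the scatter is not expected. The step expected in this assay is a 1.2-fold higher number from compound 1 to compound 3 (0.07 log units; within the scatter), with no firm direction. The estimate for compound 3 is 2800 nM, with an expected range from 1100 nM to 6500 nM.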

Compound 3, half-maximal inhibitory concentration: 3070 nM
For compound 3 the middle estimate is 1.1-fold (0.04 log units) below the measured one, and the stated range covers the measured number.
By their numbers in this assay, from the lowest: compounds 1, 3 and 2 (each within the scatter of the next).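

Methoxy in place of hydrogen, ortho to a methoxy group, gives a 1.3-fold higher number from compound 1 to compound 3 (0.11 log units; within the scatter) in this assay. Unlike the earlier step, which swapped a group already on the ring, this one fills a ring position that carries only hydrogen in compound 1, and compound 3 cannot be told apart from compound 1. No outside measurement bears on this result. As far as these compounds go, whether an amine, a carboxylic acid or a longer chain at this position would separate from compound 1 remains open.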